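This account rests on a few compounds, and the source may have more. Where it says the series, first, only, none or still open, it means among the compounds named here.

Compounds measured so far:
- compound 1 `CN1CCCN(CCn2ccc3ccc(C(N)=O)cc32)CC1`: 33%
- compound 2 `C=C(C)c1ccc2ccn(CCN3CCCN(C)CC3)c2c1`: 72%

In an assay on HEK293 cells for binding affinity to 5-hydroxytryptamine receptor 7 (Homo sapiens), read by radioligand binding, tested at 1 uM (a higher number here means more inhibition at the concentration tested (going by the name of the read-out), a lower number less inhibition), compound 2 gives 72%, the higher of the two numbers; compound 1 stands well below it, as the step of a number 39 percentage points higher from compound 1 to compound 2 (beyond the scatter) shows. Compound 3 `CN1CCCN(CCn2ccc3ccc(-c4cccnc4)cc32)CC1` is not yet measured. It differs from compound 2 in one place: pyridin-3-yl in place of 1-methylethenyl on an aromatic carbon. Within the data shown here, the only measured step that bears on this is the exchange on the same aromatic carbon from carbamoyl to 1-methylethenyl, which raised inhibition by a large amount. Pyridin-3-yl is neither of these groups, so a moderate drop from compound 2 is expected, about a number 17 percentage points lower from compound 2 to compound 3 (beyond the scatter). Compound 3 is estimated at 55%, within 30% to 80%.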

Compound 3, a percentage reported as inhibition, at one concentration (the size of the read-out at that concentration, not a potency): 35%
For compound 3 the middle estimate is 20 percentage points above the measured one; the measured number falls inside the stated range.
By their numbers in this assay, from the lowest: compounds 1 and 3 (each within the scatter of the next); then compound 2.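

At this aromatic carbon, in this assay, the high number of compound 2 does not carry over to a larger aromatic substituent: pyridin-3-yl gives a large step (a number 37 percentage points lower from compound 2 to compound 3 (beyond the scatter)). Pyridin-3-yl and carbamoyl are not separated (a number 2 percentage points higher from compound 1 to compound 3 (within the scatter)), so of the three groups only 1-methylethenyl stands apart. Nothing available explains this difference.

From the compounds shown here alone, whether phenyl, which lacks the ring nitrogen of pyridin-3-yl, would stand with compound 2 or compound 3 remains open. So does the outcome for isopropyl, the saturated counterpart of 1-methylethenyl, at this carbon.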